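The source may hold more compounds than are shown below. What is called first, only, known or untested is meant among the compounds shown, and "the series" means these compounds.

Measured so far:
Compound 1, `Cc1ccc(Cc2ccc3ccccc3c2O)cc1`, in an assay on RBL-1 cells with Polyunsaturated fatty acid 5-lipoxygenase (Rattus norvegicus) as the target (a lower number here means a stronger inhibitor, a higher number a weaker inhibitor), gives 24 nM.
Compound 2, `CN(C)c1ccc(Cc2ccc3ccccc3c2O)cc1`, in this assay gives 140 nM.

Compound 2 stands at the higher of the two numbers, so it is the weaker inhibitor of the pair measured so far. Among the measured compounds shown here, the single step between these two, a 5.8-fold higher number from compound 1 to compound 2 (0.77 log units; beyond the scatter), shows that exchanging the methyl for a dimethylamino on the aromatic carbon of the shared core raised the number beyond the scatter.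

Compound 3, `Oc1c(Cc2ccc(Cl)cc2)ccc2ccccc12`, has not yet been measured. It differs from compound 2 in one place: chloro in place of dimethylamino on an aromatic carbon. For the measured compounds named here, the only measured step that bears on this position is the one from compound 1 to compound 2, which replaced a small group with the dimethylamino and cost potency. Taking the dimethylamino away again, this time for a chloro, is therefore expected to reverse most of that loss, so the step of a 4.0-fold lower number from compound 2 to compound 3 (0.60 log units; beyond the scatter) is expected. For compound 3 the estimate in this assay is 35 nM, with a range from 12 nM to 100 nM.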

Compound 3, half-maximal inhibitory concentration: 39 nM
For compound 3 the middle estimate is 1.1-fold (0.05 log units) below the measured one, and the stated range covers the measured number.
By their numbers in this assay, from the lowest: compounds 1 and 3 (each within the scatter of the next); then compound 2.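

The higher number of compound 2 is not a fixed feature of this position: with a 3.6-fold lower number from compound 2 to compound 3 (0.56 log units; beyond the scatter) the chloro brings the number back down, so a group here can keep the compound a strong inhibitor. Chloro and methyl cannot be told apart in this assay, as a 1.6-fold higher number from compound 1 to compound 3 (0.21 log units; within the scatter) lies within the scatter, which leaves dimethylamino as the one group of the three whose number stands apart. Nothing measured here explains why the dimethylamino differs from the other two groups. The compounds shown leave open whether a primary amine at this position would behave like the dimethylamino or like the chloro. They also leave open how a carboxylic acid or a longer chain in this place would compare.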